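Swapping the Para Substituent: Methyl to Methoxy

A few compounds are considered here, and "the series" means these few. Any claim that something is new, unique, unknown or untested is made for them only; others in the source may bear on it.

Compound 1 `O=C(CCCCCn1cc(Nc2ncc3ccn(Cc4ccc(F)cc4)c3n2)cn1)NO`: 46%
Compound 2 `O=C(CCCCCn1cc(Nc2ncc3ccn(Cc4ccc(Cl)cc4)c3n2)cn1)NO`: 38%
Compound 3 `Cc1ccc(Cn2ccc3cnc(Nc4cnn(CCCCCC(=O)NO)c4)nc32)cc1`: 34%

All three share one core and differ only in the group on the benzyl ring. In an assay on isolated protein for inhibition of protein deacetylase HDAC6 (Homo sapiens), with a stated time of 60 min, tested at 10 nM (on this read-out higher numbers stand for more inhibition at the one concentration tested (going by the name of the read-out) and lower numbers for less inhibition), compound 3 gives 34%. Its position is set by two steps: a number 12 percentage points lower from compound 1 to compound 3 (beyond the scatter), and a number 4 percentage points lower from compound 2 to compound 3 (within the scatter). Compound 4 `COc1ccc(Cn2ccc3cnc(Nc4cnn(CCCCCC(=O)NO)c4)nc32)cc1` carries the change (methoxy in place of methyl on an aromatic carbon). Among the compounds with values here, no measured step involves methoxy, but the three swaps at this same aromatic carbon shifted the read-out only modestly: a number 8 percentage points lower from compound 1 to compound 2 (within the scatter) and the two just named. A step of similar or smaller size is therefore expected for this assay, with no clear direction beyond the scatter. Compound 4 is estimated at 36%, between 24% and 48%, which means an expected step of a number 2 percentage points higher from compound 3 to compound 4 (within the scatter).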

Compound 4, a percentage reported as inhibition, at one concentration (the size of the read-out at that concentration, not a potency): 46%
Compound 4: middle estimate off by 10 percentage points, on the low side, and the stated range covers the measured number.
By their numbers in this assay, from the lowest: compounds 3, 2, 1 and 4 (each within the scatter of the next, the first and the last beyond it).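

In this assay, methoxy in place of methyl gives a step that lies beyond the scatter: a number 12 percentage points higher from compound 3 to compound 4 (beyond the scatter). The other two comparisons stay within the scatter, a number 8 percentage points higher from compound 2 to compound 4 (within the scatter) and no change at the digits printed from compound 1 to compound 4 (within the scatter), so compound 3 now stands clearly apart from both compound 1 and compound 4, while compound 2 does not stand clearly apart from any of the others. Nothing available explains why methyl and methoxy differ here.

Going by these compounds, whether an amine or a carboxylic acid on this same carbon would give a larger step remains open. A single tested concentration also leaves the potency of these compounds open.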